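This account rests on a few compounds, and the source may have more. Where it says the series, first, only, none or still open, it means among the compounds named here.

Measured so far:
compound 1, `COc1cccc(OC)c1OCCNCCOc1ccccc1OCc1ccccc1`: 8.3
compound 2, `COc1cccc(Cl)c1OCCNCCOc1ccccc1OCc1ccccc1`: 7.84
compound 3, `COc1cccc(C)c1OCCNCCOc1ccccc1OCc1ccccc1`: 7.91

All three were tested in a functional assay on spleen (strain Wistar) for antagonist activity at Alpha-1B adrenergic receptor (Rattus norvegicus); a higher number here means a more potent compound, by a factor of ten per unit of this negative logarithm, a lower number a less potent compound. Compound 3 stands second highest of these three numbers: its nearest neighbour is compound 2, within the scatter, and its furthest is compound 1, beyond the scatter. Compound 4, `Cc1cccc(C)c1OCCNCCOc1ccccc1OCc1ccccc1`, has not yet been measured. It differs from compound 3 by methyl in place of methoxy on an aromatic carbon. For the measured compounds named here, one measured step bears on this directly, the same exchange within the shared core: a number 0.39 log units lower from compound 1 to compound 3 (beyond the scatter). The related step of a number 0.46 log units lower from compound 1 to compound 2 (beyond the scatter) was of similar size. A modest decrease is therefore expected for compound 4, roughly a number 0.36 log units lower from compound 3 to compound 4 (beyond the scatter). Compound 4 is estimated to reach 7.55 in this assay, with a likely range from 7.1 to 8.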

Compound 4, negative logarithm of the antagonist equilibrium constant: 7.78
The estimate for compound 4 lay 0.23 log units below the measured number; low and high end bracket the measured number.
By their numbers in this assay, from the lowest: compounds 4, 2 and 3 (each within the scatter of the next); then compound 1.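

Exchanging methoxy for methyl in the shared core does not always give a step of the same size: in this assay there is a number 0.39 log units lower from compound 1 to compound 3 (beyond the scatter) beyond the scatter, but a number 0.13 log units lower from compound 3 to compound 4 (within the scatter) within it. With a number 0.06 log units lower from compound 2 to compound 4 (within the scatter) as well, compounds 2, 3 and 4 cannot be told apart here. Only the dimethoxy compound stands apart, with a number 0.52 log units lower from compound 1 to compound 4 (beyond the scatter) for losing both methoxy groups.

Nothing measured here explains these numbers. Going by these compounds, how an ethoxy group, a hydroxyl group or an amine at this position would read remains open.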